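The source may hold more compounds than are shown below. What is called first, only, known or untested is meant among the compounds shown, and "the series" means these compounds.

Compound 1, `Nc1scc(CN2CCN(c3ccncc3)CC2)c1C(=O)c1ccc(Cl)cc1`, gives 1% in an assay on CHO cells for displacement of a labelled ligand from adenosine receptor A1 (Homo sapiens), read by scintillation counting, with a stated time of 120 min, tested at 10 uM; on this read-out lower numbers stand for less inhibition and higher numbers for more inhibition at the one concentration tested (going by the name of the read-out).
Compound 2, `Nc1scc(CN2CCC(c3ccc(Cl)cc3)CC2)c1C(=O)c1ccc(Cl)cc1`, gives 0% in this assay.
Compound 3, `Nc1scc(CN2CCN(c3c(F)cccc3F)CC2)c1C(=O)c1cccc(C(F)(F)F)c1`, gives 0% in this assay.

In this assay compound 1 gives 1%, the highest of the three numbers, yet both other compounds sit within the scatter of it: compound 2 gives 0% and compound 3 gives 0%. None of the three shows inhibition that can be told from no inhibition at all.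

Compound 4, `Nc1scc(CN2CCN(c3cccc(Cl)c3)CC2)c1C(=O)c1ccc(Cl)cc1`, is not yet measured. Against compound 1 it carries 3-chlorophenyl in place of pyridin-4-yl on an amine nitrogen in a ring. Within the data shown here, no step between measured compounds is available, and every measured number lies near the floor, so no step beyond the scatter is expected in this assay in either direction. Compound 4 is expected to give 2%, within -8% to 12%. That expectation amounts to a step of a number 1 percentage points higher from compound 1 to compound 4 (within the scatter), expected to stay inside the scatter.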

Compound 4, a percentage reported as inhibition, at one concentration (the size of the read-out at that concentration, not a potency): 0%
The estimate for compound 4 lay 2 percentage points above the measured number; the measured number falls inside the stated range.
By their numbers in this assay, from the lowest: compounds 2, 3, 4 and 1 (each within the scatter of the next).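

this assay gives a number 1 percentage points lower from compound 1 to compound 4 (within the scatter) with 3-chlorophenyl in place of pyridin-4-yl on an amine nitrogen in a ring, the first comparison in one place. At this position, exchanging the pyridin-4-yl with its hydrogen-bond acceptor for a carbon-only ring bearing chlorine leaves the read-out at the floor, with no change that can be told from scatter. No measured information bears on this result.

From the compounds shown here alone, whether a carboxylic acid or a longer chain carrying an amine at this position would lift the number clear of the scatter stays open. Also open, going by these compounds, is whether any compound on the shared core shows real inhibition in this assay at all.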